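Methyl removal on the cyclobutane: transfer from the pyridyl to the phenyl series

The source may hold more compounds than are shown below. What is called first, only, known or untested is meant among the compounds shown, and "the series" means these compounds.

Measured so far:
compound 1, `C[C@]1(O)C[C@@](c2cccc(C(F)(F)F)c2)([C@H](O)c2ccccn2)C1`: 300 nM
compound 2, `O[C@H](c1ccccn1)[C@]1(c2ccnc(C(F)(F)F)c2)C[C@@H](O)C1`: 530 nM
compound 3, `C[C@]1(O)C[C@@](c2ccnc(C(F)(F)F)c2)([C@H](O)c2ccccn2)C1`: 4270 nM

All three values come from an assay on HEK293 cells for antagonist activity at transient receptor potential cation channel subfamily V member 3 (Homo sapiens), read by FLIPR and calcium flux; a higher number here means a weaker inhibitor, a lower number a stronger inhibitor. Compound 1 has the lowest number of the three, but its gap to compound 2 is within the scatter; only its gap to compound 3 is beyond it. The difference between the core of compound 1 and the core of compound 3 is not broken down here.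

One change is seen in two pairs. From compound 3 to compound 2 the change is hydrogen in place of methyl on a saturated ring carbon, and it gives an 8.1-fold lower number from compound 3 to compound 2 (0.91 log units; beyond the scatter). The same change, (hydrogen in place of methyl on a saturated ring carbon), leads from compound 1 to compound 4, `O[C@H](c1ccccn1)[C@]1(c2cccc(C(F)(F)F)c2)C[C@@H](O)C1`, not yet measured. Its place is the same in both pairs, so it is taken as the same change.

Going by the values given here, for compound 4 a step of about a 4.3-fold lower number from compound 1 to compound 4 (0.63 log units; beyond the scatter) is expected, somewhat smaller than the one from compound 3 to compound 2, because compound 1 already stands at 300 nM and the transfer of a single step between two cores is not secured by more than one pair. Compound 4 is estimated at 70 nM, within 25 nM to 200 nM.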

Compound 4, antagonist equilibrium constant: 210 nM
Beside the measured number, compound 4's estimate is 3.0-fold (0.48 log units) below it; measured number outside the range, above it.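

In this assay, going by these compounds alone, hydrogen in place of methyl on a saturated ring carbon gives a 1.4-fold lower number from compound 1 to compound 4 (0.15 log units; within the scatter), so on the core of compound 1 this change produces no step that can be told from the usual scatter of repeated measurements. The change therefore does not carry over at the same size from one core to the other: the same change on two cores in this assay, an 8.1-fold lower number (0.91 log units; beyond the scatter) from compound 3 to compound 2 and a 1.4-fold lower number (0.15 log units; within the scatter) from compound 1 to compound 4, 5.6-fold (0.75 log units) apart, beyond the scatter of two such steps

With one pair on each core, these data give no reason for the difference and no rule for predicting the step on a further core. The compounds shown leave open how an ethyl group or a fluorine atom on that saturated ring carbon would read in this assay. Also open, from the compounds shown here alone, is whether an amine in place of the hydroxy group on the same ring carbon would give a step that differs between the two cores in the same way.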